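Swapping Chloro for Bromo in Compound 4

This account rests on a few compounds, and the source may have more. Where it says the series, first, only, none or still open, it means among the compounds named here.

Of the compounds shown here, three built on a shared core have been measured in a functional assay; on this read-out lower numbers stand for stronger inhibition and higher numbers for weaker inhibition. Compound 1 `CC(C)=CCOc1ccc2c(c1)OC(c1ccccc1Cl)CC2=O` gives 8020 nM, compound 2 `COc1ccc(C2CC(=O)c3ccc(OCC=C(C)C)cc3O2)cc1` gives 10200 nM, and compound 3 `CC(C)=CCOc1cc(O)c2c(c1)OC(c1ccccc1Cl)CC2=O` gives 4270 nM. Compound 3 thus sits within the scatter of compound 1, while its number lies below that of compound 2 by more than the scatter.

The next compound, compound 4 `CC(C)=CCOc1cc(O)c2c(c1)OC(c1ccccc1Br)CC2=O`, differs from compound 3 in a single atom: bromo in place of chloro on an aromatic carbon. This puts bromo in place of chloro on an aromatic carbon, ortho to a large group, turning 2-chlorophenyl into 2-bromophenyl.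

Going by the values given here, no measured pair makes this exact swap, so the evidence is indirect. The closest change replaces the whole 2-chlorophenyl with 4-methoxyphenyl on a saturated ring carbon and gives a 1.3-fold higher number from compound 1 to compound 2 (0.10 log units; within the scatter). The other measured change, hydroxy in place of hydrogen on an aromatic carbon, gives a 1.9-fold lower number from compound 1 to compound 3 (0.27 log units; within the scatter) and leaves the halogen untouched. Neither step goes beyond the scatter, so a swap of one halogen for another is expected to produce no clear shift in this assay. The estimated step is a 1.1-fold lower number from compound 3 to compound 4 (0.03 log units; within the scatter). For compound 4 the expected value is 4000 nM, with an estimated range from 2000 nM to 8000 nM.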

Compound 4, half-maximal inhibitory concentration: 3820 nM
Compound 4: middle estimate off by 1.0-fold (0.02 log units), on the high side, within the range that was stated.
By their numbers in this assay, from the lowest: compounds 4, 3, 1 and 2 (each within the scatter of the next, the first and the last beyond it).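

In this assay the swap of bromo for chloro on an aromatic carbon, ortho to a large group, gives a 1.1-fold lower number from compound 3 to compound 4 (0.05 log units; within the scatter) and so leaves compound 3 and compound 4 indistinguishable on this read-out. Going by these compounds alone, the earlier steps could only hint at this, since the one change at this ring replaced the whole 2-chlorophenyl with 4-methoxyphenyl; here the halogen alone differs while the rest of the molecule stays fixed. At this position, then, 2-bromophenyl and 2-chlorophenyl cannot be told apart, and no accompanying measurement offers any account of why the two read alike.

The compounds shown carry only these two halogens on this carbon, so it remains open whether a very different group there, such as an amine, a carboxylic acid or a nitrile, would shift the number beyond the scatter. Going by these compounds, it also remains open whether bromo and chloro would still read alike on the core of compound 1, which lacks the hydroxy group that compound 3 and compound 4 share.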